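Sulfonyloxyphenyl acrylamide thiadiazoles: growth inhibition working notes

The compounds below may be only part of what the source reports. "The series", "measured", "known", "first", "only" and "open" are said of these compounds alone.

Measured so far:
- compound 1 `COc1ccc(Cc2nnc(NC(=O)/C(C#N)=C/c3ccccc3OS(=O)(=O)c3ccc(C)cc3)s2)cc1` gives 21% in an ADME assay on HEK-293T cells (Homo sapiens) for inhibition, read by CCK-8 assay, with a stated time of 48 h, tested at 20 uM; on this read-out lower numbers stand for less inhibition of growth and higher numbers for more inhibition of growth at the one concentration tested
- compound 2 `COc1ccc(Cc2nnc(NC(=O)/C(C#N)=C/c3ccccc3OS(=O)(=O)c3ccc(OC)cc3)s2)cc1` gives 30% in this assay
- compound 3 `Cc1ccc(S(=O)(=O)Oc2ccccc2/C=C(\C#N)C(=O)Nc2nnc(Cc3cccc(F)c3)s2)cc1` gives 9% in this assay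

Compound 4 `COc1ccc(S(=O)(=O)Oc2ccccc2/C=C(\C#N)C(=O)Nc2nnc(Cc3cccc(F)c3)s2)cc1` is not yet measured. It differs from compound 3 by methoxy in place of methyl on an aromatic carbon. The same change separates compound 1 from compound 2, where the read-out moved a number 9 percentage points higher from compound 1 to compound 2 (within the scatter). The place of the change is described in the same words for both pairs, so it is the same change. The two cores differ by 3-fluorophenyl in place of 4-methoxyphenyl on a saturated chain carbon bound to an aromatic carbon, and on that change the read-out moved a number 12 percentage points lower from compound 1 to compound 3 (beyond the scatter). Compound 3 thus stands lowest of the three measured numbers, beyond the scatter from both others.

Among the compounds with values here, for compound 4 a step of the same size as the earlier one is expected, a number 7 percentage points higher from compound 3 to compound 4 (within the scatter), which rests on the single measured pair, compound 1 to compound 2 a number 9 percentage points higher from compound 1 to compound 2 (within the scatter). Within the data shown here, only one example of this change is in hand, so the expectation is loosely held. Compound 4 is estimated at 16% in this assay, between 5% and 28%.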

Compound 4, percent growth inhibition at one concentration: 29%
Estimate against measurement, compound 4: 13 percentage points below; measured number outside the range, above it.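

Methoxy in place of methyl on the aromatic carbon gives a number 20 percentage points higher from compound 3 to compound 4 (beyond the scatter) in this assay, and the two readings of this change agree as far as the scatter allows: the same change on two cores in this assay, a number 9 percentage points higher (within the scatter) from compound 1 to compound 2 and a number 20 percentage points higher (beyond the scatter) from compound 3 to compound 4, 11 percentage points apart, within the scatter of two such steps. On the other axis of the set, 3-fluorophenyl in place of 4-methoxyphenyl gives a number 1 percentage points lower from compound 2 to compound 4 (within the scatter), and this step too stays in reach of its earlier counterpart: the same change on two cores in this assay, a number 12 percentage points lower (beyond the scatter) from compound 1 to compound 3 and a number 1 percentage points lower (within the scatter) from compound 2 to compound 4, 11 percentage points apart, within the scatter of two such steps. The two pairs fit a single methoxy step carried from one core to the other, but the earlier step lies within the scatter, so they fix neither its size nor its reach beyond these two cores.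

The compounds shown hold only methyl and methoxy on this aromatic ring, and only 4-methoxyphenyl and 3-fluorophenyl on the saturated chain carbon. From the compounds shown here alone, whether a chlorine, a dimethylamino group or a carboxylic acid in place of the methoxy would keep the read-out in this assay at the level of compound 4 remains open.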